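This account rests on a few compounds, and the source may have more. Where it says the series, first, only, none or still open, it means among the compounds named here.

Of the compounds shown here, three have been measured in a functional assay on A549 cells (Homo sapiens) for inhibition, read by MTT assay, with a stated time of 24 h; on this read-out lower numbers stand for stronger inhibition and higher numbers for weaker inhibition.

Compound 1, `CCOC(=O)C1=Cc2ccccc2OC1(OCc1cn(CC(=O)Nc2cccc(F)c2)nn1)C(F)(F)F`, gives > 150000 nM, which is a limit and not a number.
Compound 2, `CCOC(=O)C1=Cc2ccccc2OC1(OCc1cc(-c2ccc(Br)cc2)no1)C(F)(F)F`, gives > 150000 nM, likewise a limit.
Compound 3, `O=C(O)C1=Cc2ccccc2OC1(OCc1cc(-c2ccc([N+](=O)[O-])cc2)no1)C(F)(F)F`, gives > 150000 nM, again a limit.

For compound 1 there is therefore only a limit and no number, and the same holds for compound 2 and compound 3; all three results sit at the limit of > 150000 nM in this assay, at which 3 of the 3 values shown sit. Among the measured compounds shown here, no step between measured compounds that differ in one place can be drawn, since every value is a limit. The unmeasured compound 4, `CCOC(=O)C1=Cc2ccccc2OC1(OCc1cn(CC(=O)Nc2cccc(Cl)c2)nn1)C(F)(F)F`, differs from compound 1 in one place: chloro in place of fluoro on an aromatic carbon. For the measured compounds named here, nothing among the measured compounds shows how this change behaves in this assay, and compound 1 itself gave no number that a step could be set against. The expected step is a number no higher from compound 1 to compound 4 (the limit leaves the size open), which is to say no change beyond the usual scatter, so that compound 4 is expected most often to return only a limit as well. For compound 4 the estimate in this assay is 150000 nM, with a range from 50000 nM to 400000 nM.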

Compound 4, half-maximal inhibitory concentration: 12800 nM
For compound 4 the middle estimate is 12-fold (1.07 log units) above the measured one, and the stated range ends above it.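

In this assay, chloro in place of fluoro on an aromatic carbon, meta to a large group, gives an at least 11-fold lower number from compound 1 to compound 4 (1.06 log units; beyond the scatter). Among the compounds shown here, the earlier compounds offered no number at all, and this single-atom change at this position is the first to bring a compound off the limit that holds the others: the limit of > 150000 nM in this assay, at which 3 of the 4 values shown sit. The finding rests on this one pair, the 3-fluorophenyl and 3-chlorophenyl compounds, and the compounds shown give no way to tell why the change has so large an effect.

The compounds shown leave open whether a methyl, a methoxy or a nitrile in place of chloro on this same aromatic carbon would lower the number further, keep it or return it to the limit. They also leave open whether chloro in place of fluoro would have a similar effect if the ethyl ester of the shared core were replaced by a carboxylic acid, or if the (3-chlorophenyl)carbamoyl group were carried on a longer chain.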